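A few compounds are considered here, and "the series" means these few. Any claim that something is new, unique, unknown or untested is made for them only; others in the source may bear on it.

Measured so far:
compound 1 `O=C1C2=C(CCCC2)C(=O)N1c1ccc(Cl)cc1F`: 5.01 nM
compound 2 `CC(C)OC(=O)c1cc(N2C(=O)C3=C(CCCC3)C2=O)c(F)cc1Cl`: 7.94 nM

Both numbers come from an assay on isolated protein (Echinochloa esculenta) for inhibition of protoporphyrinogen oxidase, chloroplastic (Oryza sativa subsp. japonica), using a Dixon plot, with a stated time of 5 min; on this read-out lower numbers stand for stronger inhibition and higher numbers for weaker inhibition. Going by the values given here, compound 2 stands beside compound 1 as the only other measured compound; the step between them, a 1.6-fold higher number from compound 1 to compound 2 (0.20 log units; within the scatter), lies within the scatter, so neither compound is set apart from the other. Compound 3 `C#CCOc1cc(N2C(=O)C3=C(CCCC3)C2=O)c(F)cc1Cl` differs from compound 2 in one place: propargyloxy in place of isopropoxycarbonyl on an aromatic carbon. Among the compounds with values here, the single measured step, a 1.6-fold higher number from compound 1 to compound 2 (0.20 log units; within the scatter), concerns the same aromatic carbon and shows that placing a group there left the number essentially where it was. Nothing measured here separates propargyloxy from isopropoxycarbonyl at that carbon, so the step of a 1.3-fold lower number from compound 2 to compound 3 (0.12 log units; within the scatter) is expected to stay within the scatter, with no direction favored. On that basis compound 3 is estimated at 6 nM in this assay, with a range from 2 nM to 20 nM.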

Compound 3, half-maximal inhibitory concentration: 3.16 nM
Estimate against measurement, compound 3: 1.9-fold (0.28 log units) above; the range from low to high includes it.
By their numbers in this assay, from the lowest: compounds 3, 1 and 2 (each within the scatter of the next, the first and the last beyond it).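

In this assay, going by these compounds alone, the aromatic carbon ortho to the chloro group and para to the fluoro group now separates two groups: a 2.5-fold lower number from compound 2 to compound 3 (0.40 log units; beyond the scatter) is the only step at this position that lies beyond the scatter. Neither group is set apart from hydrogen at that carbon, since a 1.6-fold lower number from compound 1 to compound 3 (0.20 log units; within the scatter) stays within the scatter, as does a 1.6-fold higher number from compound 1 to compound 2 (0.20 log units; within the scatter), so the two groups differ from each other without either differing from the unsubstituted compound. No evidence bearing on the reason for this difference is at hand.

The compounds shown leave open whether the separation follows the triple bond of propargyloxy, its ether oxygen or the loss of the ester. A propoxy or allyloxy group at the same carbon, or a carboxylic acid there, remains unplaced among these numbers.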